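Removing one chlorine from a purine-like core

The source may hold more compounds than are shown below. What is called first, only, known or untested is meant among the compounds shown, and "the series" means these compounds.

Compound 1 `ClCc1ccc(Cn2cnc3c(Cl)ncnc32)cc1` and compound 2 `ClCc1ccc(Cn2cnc3nc(Cl)nc(Cl)c32)cc1` share the same chloromethyl-benzyl group on a fused two-ring core. In a functional assay on COLO 205 cells (Homo sapiens) for cytotoxicity, read by sulforhodamine B assay, with a stated time of 48 h (a higher number here means a weaker inhibitor of growth, a lower number a stronger inhibitor of growth), compound 1 gives only a limit of the assay, > 100000 nM. In this assay compound 2 likewise reaches only a limit, > 100000 nM. Compound 2 therefore stands at the edge of what this assay can report, as does the other value shown (the limit of > 100000 nM in this assay, at which 2 of the 2 values shown sit). Compound 3 `ClCc1ccc(Cn2cnc3ncnc(Cl)c32)cc1` differs from compound 2 by hydrogen in place of chloro on an aromatic carbon. With both measured values sitting at a limit, no step beyond the scatter can be expected from compound 2 to compound 3 a step that the limit leaves unreadable from compound 2 to compound 3. Compound 3 is therefore estimated at 150000 nM, within 40000 nM to 600000 nM, most likely again only a limit.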

Compound 3, concentration for total growth inhibition: 3800 nM
Compound 3: the middle estimate sits 39-fold (1.60 log units) above what was measured, outside the stated range (below it).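

Hydrogen in place of the chloro group on the aromatic carbon between two ring nitrogen atoms gives an at least 26-fold lower number from compound 2 to compound 3 (1.42 log units; beyond the scatter) in this assay and so shows that what sits on this carbon matters. The earlier compounds shown here gave no measured number to compare, whereas compound 3 does. The full size of the step cannot be read, because compound 2 gives only a limit: the limit of > 100000 nM in this assay, at which 2 of the 3 values shown sit.

The compounds shown leave open whether only hydrogen works on this carbon, or whether an amine or a methoxy group would also give a measured number.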